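The source may hold more compounds than are shown below. What is called first, only, known or untested is meant among the compounds shown, and "the series" means these compounds.

Working notes on the series. The shared core is seen in compound 1 `Cc1nn(C)c(C)c1-c1ccc(-c2nnc(N(C)Cc3ccc4nccn4c3)o2)cc1`, which in an assay on isolated protein for inhibition of tyrosine-protein kinase receptor UFO (Homo sapiens), read by LC-MS (on this read-out lower numbers stand for stronger inhibition and higher numbers for weaker inhibition), gives 1260 nM. Compound 2 `Cc1cc(-c2c(C)nn(C)c2C)ccc1-c1nnc(N(C)Cc2ccc3nccn3c2)o1` gives 79.4 nM in this assay, and the step of a 16-fold lower number from compound 1 to compound 2 (1.20 log units; beyond the scatter). Compound 3 `Cc1cc(-c2c(C)n[nH]c2C)ccc1-c1nnc(N(C)Cc2ccc3nccn3c2)o1` gives 5010 nM, and the step of a 63-fold higher number from compound 2 to compound 3 (1.80 log units; beyond the scatter). Compound 3 therefore stands with the highest number of the three measured, its nearest neighbour being compound 1 and compound 2 lying furthest from it.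

The next change in the series leads to compound 4 `Cc1cc(-c2c(C#N)nn(C)c2C)ccc1-c1nnc(N(C)Cc2ccc3nccn3c2)o1`, the structural change from compound 3 being (3-cyano-1,5-dimethyl-1H-pyrazol-4-yl in place of 3,5-dimethyl-1H-pyrazol-4-yl on an aromatic carbon). Two elements are in play: the entering group again carries a methyl on the aromatic nitrogen, as compound 2 does, and a nitrile stands where one methyl of the leaving group stood. The step bearing on the first element is a 63-fold higher number from compound 2 to compound 3 (1.80 log units; beyond the scatter), a large step which this change runs in reverse. Among the measured compounds shown here, nothing among the measured compounds bears on the nitrile; no compound here carries one. On this basis a large step toward a lower number is expected, roughly of the size seen between compound 2 and compound 3, with added uncertainty from the nitrile.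

Compound 4 is therefore expected to give about 150 nM in this assay, within a range from 40 nM to 600 nM, the expected step being a 33-fold lower number from compound 3 to compound 4 (1.52 log units; beyond the scatter).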

Compound 4, half-maximal inhibitory concentration in the tyrosine-protein kinase receptor UFO assay: 6310 nM
For compound 4 the middle estimate is 42-fold (1.62 log units) below the measured one; the whole stated range lies below it.
By their numbers in the tyrosine-protein kinase receptor UFO assay, from the lowest: compound 2; then compound 1; then compounds 3 and 4 (each within the scatter of the next).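

In the tyrosine-protein kinase receptor UFO assay the exchange of 3,5-dimethyl-1H-pyrazol-4-yl for 3-cyano-1,5-dimethyl-1H-pyrazol-4-yl gives a 1.3-fold higher number from compound 3 to compound 4 (0.10 log units; within the scatter), so a methyl on the aromatic nitrogen does not by itself bring back the number of compound 2 when a nitrile is present on the pyrazole. Among the compounds shown here, the single change of cyano in place of methyl on an aromatic carbon gives a 79-fold higher number from compound 2 to compound 4 (1.90 log units; beyond the scatter), which shows that this carbon of the pyrazole, as well as the aromatic nitrogen, carries a large step. In a physicochemical assay for lipophilicity, at pH 7.4 (a higher number here means a more lipophilic compound, a lower number a more polar compound), compound 3 gives 3.8 and compound 4 gives 3.4. The exchange that leaves the tyrosine-protein kinase receptor UFO assay within the scatter does register in the physicochemical assay, with compound 4 the more polar of the pair: the measured distribution coefficient of compound 3, 3.8, and of compound 4, 3.4, a number 0.40 log units lower (beyond the scatter)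

On these data alone, whether the large step at this carbon belongs to the nitrile in particular or would follow any replacement of the methyl stays open, and a chlorine atom, an ethyl group or a primary amide at this place would help to separate the two readings. Also open, as far as these compounds go, is how the nitrile would read with the hydrogen on the aromatic nitrogen that compound 3 carries, a pairing that would show whether the two changes act independently.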